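The source may hold more compounds than are shown below. What is called first, only, known or untested is meant among the compounds shown, and "the series" means these compounds.

Of the compounds shown here, two that share one core have so far been measured in an in vitro ADME assay on microsomes (Homo sapiens) for metabolic stability; a lower number here means that the compound disappears faster, a higher number that the compound lasts longer. Among the measured compounds shown here, compound 1 `CNC(=O)Nc1ccc(-c2nc(N3CC4CCC(C3)O4)c3cnn(C(C)C)c3n2)cc1` gives 0.2 h, and compound 2 `CNC(=O)Nc1ccc(-c2nc(N3CC4CCC(C3)O4)c3cnn([C@H]4CC[C@H](OC)CC4)c3n2)cc1` gives 0.25 h, so compound 2 lies within the scatter of the only other number available. Compound 3 `CNC(=O)Nc1ccc(-c2nc(N3CC4CCC(C3)O4)c3cnn([C@H]4CC[C@H](O)CC4)c3n2)cc1` has not yet been measured. It differs from compound 2 by one small change: hydrogen in place of methyl on an oxygen on a saturated carbon. Put simply, hydrogen takes the place of methyl on an oxygen on a saturated carbon, which turns 4-methoxycyclohexyl into 4-hydroxycyclohexyl.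

For the measured compounds named here, only one measured step bears on this, and only loosely: a 1.3-fold higher number from compound 1 to compound 2 (0.10 log units; within the scatter). That step also changed the group on the aromatic nitrogen, and it stayed within the scatter. Going by the values given here, no measured pair compares methoxy with hydroxy, so the data give no direction for this change. Among the compounds with values here, with only that step of a 1.3-fold higher number from compound 1 to compound 2 (0.10 log units; within the scatter) as a guide, no change beyond the scatter is expected, and the estimate is a 1.2-fold higher number from compound 2 to compound 3 (0.08 log units; within the scatter). For compound 3 the expected half-life is 0.3 h, with an estimated range from 0.15 h to 0.7 h.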

Compound 3, half-life: > 0.5 h
Compound 3: a limit, no number; the forecaster's own chance of this, stated with the estimate: 5%; middle value at least 1.6-fold (0.22 log units) away from the limit.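

In this assay compound 3 gives > 0.5 h, which is a limit of the assay and not a number. Going from methoxy to hydroxy gives an at least 2.0-fold higher number from compound 2 to compound 3 (0.30 log units; that floor lies within the scatter), so the floor of this step alone does not separate the two compounds, although the true step may be larger. Placing 4-hydroxycyclohexyl instead of isopropyl on the aromatic nitrogen gives an at least 2.5-fold higher number from compound 1 to compound 3 (0.39 log units; beyond the scatter), the first step shown here that clears the scatter, whereas 4-methoxycyclohexyl at the same place gave only a 1.3-fold higher number from compound 1 to compound 2 (0.10 log units; within the scatter), so what sits on the oxygen of this cyclohexyl group can matter for how long the compound lasts.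

On these data alone, the real size of both new steps stays open because the value of compound 3 is capped: the limit of > 0.5 h in this assay, at which 1 of the 3 values shown sits. Also open is whether an amine or a carboxylic acid in place of the hydroxy group on the cyclohexyl would behave like hydroxy or like methoxy, as the compounds shown carry neither group.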